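A few compounds are considered here, and "the series" means these few. Any claim that something is new, unique, unknown or untested is made for them only; others in the source may bear on it.

Measured compounds:
compound 1 `CC(Sc1nc2nn(C3(C)COC3)cc2c(=O)n1-c1ccccc1)c1ccccc1` — 112 nM
compound 2 `COc1cccc(C(C)Sc2nc3c(cnn3C)c(=O)n2-c2ccccc2)c1` — 108 nM
compound 3 `Cn1ccc2c(=O)n(-c3ccccc3)c(SCc3cccc(F)c3)nc21` — 810 nM

In an assay on isolated protein for inhibition of retinal dehydrogenase 2 (Homo sapiens) (a higher number here means a weaker inhibitor, a lower number a stronger inhibitor), compound 2 gives 108 nM and compound 1 gives 112 nM; the two numbers lie within the scatter of each other, so no order between them can be read. Compound 3 gives 810 nM in this assay, a gap from compound 2 that lies beyond the scatter. Among the measured compounds shown here, no two of the measured compounds differ in a single place, so no measured step is available as a guide.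

Compound 4 `CC(Sc1nc2c(cnn2C)c(=O)n1-c1ccccc1)c1cncnc1` has not been measured. It differs from compound 2 in one place: pyrimidin-5-yl in place of 3-methoxyphenyl on a saturated chain carbon bound to a saturated chain carbon and a sulfur.

For the measured compounds named here, nothing among the measured compounds speaks directly to this exchange. On the numbers available, the expectation for this assay is a modest step upward, possibly no more than the scatter allows. Compound 4 is therefore estimated at 300 nM, with a range from 100 nM to 900 nM, which means an expected step of a 2.8-fold higher number from compound 2 to compound 4 (0.44 log units; beyond the scatter).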

Compound 4, half-maximal inhibitory concentration: 380 nM
For compound 4 the middle estimate is 1.3-fold (0.10 log units) below the measured one; the range from low to high includes it.
By their numbers in this assay, from the lowest: compounds 2 and 1 (each within the scatter of the next); then compound 4; then compound 3.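

Pyrimidin-5-yl in place of 3-methoxyphenyl on a saturated chain carbon bound to a saturated chain carbon and a sulfur gives the only single-place comparison in the series, and in this assay it produces a 3.5-fold higher number from compound 2 to compound 4 (0.55 log units; beyond the scatter). The group at this position therefore affects the read-out, although this one exchange costs only a modest step and the compound stays measurable within the range of the series. No available measurement accounts for the size or direction of this step.

This single exchange does not separate the departure of the methoxy group from the entry of the ring nitrogens, a question that a pyridin-3-yl or 3-hydroxyphenyl group at this place could address. Going by these compounds, whether pyrimidin-5-yl gives a similar result on the core of compound 1 also remains open.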